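This account rests on a few compounds, and the source may have more. Where it says the series, first, only, none or still open, it means among the compounds named here.

Compound 1, `COc1ccc2nc(Nc3ccnc(Nc4ccc(S(N)(=O)=O)cc4)n3)sc2c1`, gives 11000 nM in a functional assay on MCF7 cells (Homo sapiens) for antiproliferative activity, read by MTT assay, with a stated time of 48 h; a higher number here means a weaker inhibitor, a lower number a stronger inhibitor.
Compound 2, `Cc1cnc(Nc2ccc([N+](=O)[O-])cc2)nc1Nc1nc2ccccc2s1`, reaches only the limit of the assay at > 50000 nM.
Compound 3, `COc1ccc2nc(Nc3ccnc(Nc4ccc(S(C)(=O)=O)cc4)n3)sc2c1`, also reaches only the limit of the assay at > 50000 nM.

Compound 2 thus stands at the limit of this assay; no number is known for it, only that it is one of the two values sitting at the limit of > 50000 nM in this assay, at which 2 of the 3 values shown sit. Compound 4, `Cc1cnc(Nc2ccc(S(C)(=O)=O)cc2)nc1Nc1nc2ccccc2s1`, differs from compound 2 in a single place: methylsulfonyl in place of nitro on an aromatic carbon. Among the measured compounds shown here, no measured step alters a nitro group, so none bears directly on this change. For the measured compounds named here, the only measured step, an at least 4.5-fold higher number from compound 1 to compound 3 (0.65 log units; beyond the scatter), runs from a sulfonamide to a methylsulfonyl on another core and ends at the limit, so the methylsulfonyl group did not yield a stronger inhibitor there. Compound 4 is expected to remain at the limit, giving an expected step that the limit leaves unreadable from compound 2 to compound 4 that is none beyond the scatter. Compound 4 is therefore estimated at 60000 nM, within 20000 nM to 200000 nM, most likely reported only as a limit.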

Compound 4, half-maximal inhibitory concentration: 6550 nM
Compound 4: middle estimate off by 9.2-fold (0.96 log units), on the high side; the whole stated range lies above it.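

In this assay, among the compounds shown here, nitro giving way to methylsulfonyl on an aromatic carbon para to a large group produces an at least 7.6-fold lower number from compound 2 to compound 4 (0.88 log units; beyond the scatter), the first readable number on the core of compound 2. The earlier step, an at least 4.5-fold higher number from compound 1 to compound 3 (0.65 log units; beyond the scatter), ended at the limit with methylsulfonyl on another core, so that outcome did not carry over to this core. The size of the new step is only a minimum, and how far it truly reaches cannot be read: the limit of > 50000 nM in this assay, at which 2 of the 4 values shown sit.

The compounds shown leave open whether a sulfonamide, an amine or a carboxylic acid at this position on the core of compound 2 would give a lower number than methylsulfonyl. They also leave open whether a longer chain on the sulfonyl sulfur would keep the activity of compound 4.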